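Oral tail flick series: carbamoyl to carboxy at compound 4

The source may report more compounds than this note shows. Statements on the series, on what has been measured and on what is new or still open speak of the compounds shown alone.

Of the compounds shown here, three have been measured in a functional assay on the whole organism (Tail, strain ICR) with Mus musculus as the target, in the tail flick test, with a stated time of 90 min, at a dose of 25 umol/kg by the oral route; a higher number here means a stronger effect of the compound at the dose given, a lower number a weaker effect. Compound 1 `NC(=O)CC[C@H](NC(=O)CN(c1ncnc2c1ncn2C1CCCCO1)C1CC1)C(=O)OCc1ccccc1` gives 37.8%, compound 2 `O=C(O)[C@@H]1CCCN1C(=O)CN(c1nc(Cl)nc2[nH]cnc12)C1CC1` gives 26%, and compound 3 `NC(=O)C[C@H](NC(=O)CN(c1nc(Cl)nc2[nH]cnc12)C1CC1)C(=O)O` gives 20.1% in this assay. Compound 3 sits at the low end of these numbers: its value and that of compound 2 lie within the scatter of each other, while compound 1 stands higher by a margin beyond the scatter.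

Compound 4 `O=C(O)C[C@H](NC(=O)CN(c1nc(Cl)nc2[nH]cnc12)C1CC1)C(=O)O` has not been measured in this assay. It differs from compound 3 in one place: hydroxy in place of amino on a carbonyl carbon. Going by the values given here, no measured pair in this set shows the same change, so the size of the step is not known from the data. Since every measured number in this assay is modest, and the change is small, the step from compound 3 to compound 4 is expected to stay within the scatter, a number 2.1 percentage points lower from compound 3 to compound 4 (within the scatter). Compound 4 is therefore estimated to give about 18% in this assay, within a range from 8% to 30%.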

Compound 4, a percentage reported as activity, at one dose (the size of the read-out at that dose, not a potency): 25.1%
Estimate against measurement, compound 4: 7.1 percentage points below; low and high end bracket the measured number.
By their numbers in this assay, from the lowest: compounds 3, 4 and 2 (each within the scatter of the next); then compound 1.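

With compound 3 and compound 4, this assay gains its first pair of compounds that differ in one place, and the change of carbamoyl to carboxy gives a number 5 percentage points higher from compound 3 to compound 4 (within the scatter) on this side chain. At this carbonyl carbon, whose other neighbour is a saturated chain carbon, hydroxy in place of amino therefore produces no difference that can be told from the usual scatter at this single oral dose and time. Nothing available offers an explanation for this result.

This single pair leaves open how the same place would respond to a different group, such as a methyl ester, an amine or a longer chain ending in a carboxylic acid. Going by these compounds alone, it also leaves open whether carbamoyl to carboxy would give a similar step on another side chain, such as the one in compound 1.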